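From dimethylamino to methanesulfonamido at one aromatic carbon

The source may hold more compounds than are shown below. What is called first, only, known or untested is meant among the compounds shown, and "the series" means these compounds.

In an in vivo ADME assay on the whole organism (plasma) for pharmacokinetics, with Rattus norvegicus as the target, at a dose of 50 mg/kg by the oral route (a higher number here means more compound in the circulation at the dose given, a lower number less compound in the circulation), compound 1 `Cc1cc(C)c(NC(=O)c2sccc2S(=O)(=O)Nc2onc(C)c2Cl)c(C)c1CO` gives 5110 nM while compound 2 `Cc1cc(C)c(OC2CC2)c(C)c1NC(=O)c1sccc1S(=O)(=O)Nc1onc(C)c1Cl` gives 12300 nM and compound 3 `Cc1cc(C)c(N(C)C)c(C)c1NC(=O)c1sccc1S(=O)(=O)Nc1onc(C)c1Cl` gives 6620 nM on the same shared core. Compound 3 stands second of the three numbers, but within the scatter of both neighbours, as a 1.3-fold higher number from compound 1 to compound 3 (0.11 log units; within the scatter) and a 1.9-fold lower number from compound 2 to compound 3 (0.27 log units; within the scatter) show.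

Compound 4 `Cc1cc(C)c(NS(C)(=O)=O)c(C)c1NC(=O)c1sccc1S(=O)(=O)Nc1onc(C)c1Cl` has not yet been measured. It carries methanesulfonamido in place of dimethylamino on an aromatic carbon and is otherwise the same as compound 3.

Within the data shown here, no measured step covers this exact swap. The three measured swaps at this carbon are all small, and only a 2.4-fold higher number from compound 1 to compound 2 (0.38 log units; beyond the scatter) passes the scatter, modestly. They give no direction for methanesulfonamido, so no step beyond the scatter is expected in this assay, though the uncertainty is wide. The expected change is a 1.2-fold lower number from compound 3 to compound 4 (0.08 log units; within the scatter) and remains an estimate. For compound 4 the estimated value is 5500 nM and it is expected to lie between 1800 nM and 14000 nM.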

Compound 4, maximal plasma concentration: 5250 nM
Compound 4: middle estimate off by 1.0-fold (0.02 log units), on the high side, within the range that was stated.
By their numbers in this assay, from the lowest: compounds 1, 4, 3 and 2 (each within the scatter of the next, the first and the last beyond it).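

In this assay, the step to methanesulfonamido (a 1.3-fold lower number from compound 3 to compound 4 (0.10 log units; within the scatter)) shows that adding a hydrogen-bond donor absent from dimethylamino makes no difference beyond the scatter at this carbon, and the same holds against hydroxymethyl (a 1.0-fold higher number from compound 1 to compound 4 (0.01 log units; within the scatter)). Cyclopropyloxy is separated from methanesulfonamido (a 2.3-fold lower number from compound 2 to compound 4 (0.37 log units; beyond the scatter)), as it is from hydroxymethyl but not from dimethylamino, so methanesulfonamido joins the two groups that sit closest together, and the step against cyclopropyloxy is modest. Nothing available here accounts for these readings.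

The compounds shown leave open whether a carboxylic acid or a longer alkoxy chain at this carbon would move the number further than these four groups do. They also leave open whether the edge of cyclopropyloxy over hydroxymethyl and methanesulfonamido would hold at another oral dose.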